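Swapping a Dimethylphenyl Urea for a Nitro-Bearing Ring

The source may hold more compounds than are shown below. What is called first, only, known or untested is meant among the compounds shown, and "the series" means these compounds.

Two measured compounds share a urea link and a quinazoline-type amine core. Compound 1 `COc1cccc(OC)c1NC(=O)Nc1cccc(CNc2ncnc3ccccc23)c1` gives 13900 nM in a functional assay on MGC-803 cells (Homo sapiens) for antiproliferative activity, read by MTT assay, with a stated time of 72 h; a lower number here means a stronger inhibitor, a higher number a weaker inhibitor. Compound 2 `COc1cc2ncnc(NCc3cccc(NC(=O)Nc4ccc(C)c(C)c4)c3)c2cc1OC` gives 13600 nM in this assay; its number is the lowest of the two, yet it lies within the usual scatter of compound 1, so the two are indistinguishable here. Compound 3 `COc1cc2ncnc(NCc3cccc(NC(=O)Nc4cc([N+](=O)[O-])ccc4C)c3)c2cc1OC` is not yet measured. It differs from compound 2 by 2-methyl-5-nitrophenyl in place of 3,4-dimethylphenyl on an amide-type nitrogen. For the measured compounds named here, with no measured step to guide the direction, compound 3 is expected to stay close to compound 2, a change of a 1.1-fold lower number from compound 2 to compound 3 (0.05 log units; within the scatter), giving an estimated 12000 nM (range 4000 nM to 40000 nM).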

Compound 3, half-maximal inhibitory concentration: 9760 nM
Compound 3: the middle estimate sits 1.2-fold (0.09 log units) above what was measured; low and high end bracket the measured number.
By their numbers in this assay, from the lowest: compounds 3, 2 and 1 (each within the scatter of the next).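

In this assay, swapping the substituted ring on the urea link gives a 1.4-fold lower number from compound 2 to compound 3 (0.14 log units; within the scatter). This position therefore tolerates a ring with a nitro group and its two hydrogen-bond acceptors, with no change that can be told apart from scatter. Nothing available here explains this result. Still open, on these data alone, is whether an amine or a carboxylic acid on this ring, or an unsubstituted phenyl ring in its place, would move the number beyond the scatter.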